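A few compounds are considered here, and "the series" means these few. Any claim that something is new, unique, unknown or untested is made for them only; others in the source may bear on it.

Measured in an ADME assay on GES1 cells (Homo sapiens) for cytotoxicity, read by MTT assay, with a stated time of 24 h (a lower number here means that less compound is tolerated, a higher number that more compound is tolerated), the compounds read as follows.

Compound 1 `Cc1ccccc1-n1cc(-c2ccccc2NS(=O)(=O)c2c[nH]c(=O)[nH]c2=O)nn1` gives 19900 nM here
Compound 2 `Cc1cccc(-n2cc(-c3ccccc3NS(=O)(=O)c3c[nH]c(=O)[nH]c3=O)nn2)c1` gives 23700 nM here
Compound 3 `O=c1[nH]cc(S(=O)(=O)Nc2ccccc2-c2cn(-c3ccccc3F)nn2)c(=O)[nH]1` gives > 100000 nM as a limit of the assay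

Compound 2 has one numeric neighbour and sits within the scatter of it, as a 1.2-fold higher number from compound 1 to compound 2 (0.08 log units; within the scatter) shows. Compound 4 `O=c1[nH]cc(S(=O)(=O)Nc2ccccc2-c2cn(-c3ccc(F)cc3)nn2)c(=O)[nH]1` differs from compound 2 thus: 4-fluorophenyl in place of 3-methylphenyl on an aromatic nitrogen with 4-fluorophenyl in place of 3-methylphenyl on an aromatic nitrogen. For the measured compounds named here, two measured steps bear on this: an at least 4.2-fold higher number from compound 2 to compound 3 (0.62 log units; beyond the scatter) for 2-fluorophenyl in place of 3-methylphenyl and an at least 5.0-fold higher number from compound 1 to compound 3 (0.70 log units; beyond the scatter) for fluoro in place of methyl. Going by these compounds, both end at the limit of > 100000 nM in this assay, at which 1 of the 3 values shown sits, so their true size stays open. Since 4-fluorophenyl is not 2-fluorophenyl, a more modest rise is expected. In this assay a rise beyond the scatter is expected, namely a 2.3-fold higher number from compound 2 to compound 4 (0.37 log units; beyond the scatter) as estimated here. Compound 4 is estimated at 55000 nM with a range from 20000 nM to 100000 nM for now.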

Compound 4, half-maximal cytotoxic concentration: "not toxic" (no number reported)
Compound 4 has no reported number here; no gap can be computed for the estimate.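

For the compounds shown here, compound 4 is reported only as "not toxic", without a number, so no step from compound 2 to compound 4 can be read. The compounds shown leave open where compound 4 truly lies and how large the rise to compound 3 is, as compound 3 stands at a limit: the limit of > 100000 nM in this assay, at which 1 of the 4 values shown sits.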